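A few compounds are considered here, and "the series" means these few. Any claim that something is new, unique, unknown or untested is made for them only; others in the source may bear on it.

Compound 1, with the structure `C=C1C(=O)[C@@]23C(=O)OC[C@]4(C(=O)CCC(C)(C)[C@H]4C=O)[C@@H]2CC[C@@H]1[C@H]3OC(=O)c1ccccc1`, is tested in a functional assay on Bel-7402 cells (Homo sapiens) for cytotoxicity, read by MTT assay, with a stated time of 72 h (a higher number here means a weaker inhibitor, a lower number a stronger inhibitor), and gives 1850 nM, the lowest of the two numbers recorded, although its companion lies within the scatter of it. That companion, compound 2 with the structure `C=C1C(=O)[C@@]23C(=O)OC[C@]4(C(=O)CCC(C)(C)[C@H]4C=O)[C@@H]2CC[C@@H]1[C@H]3OC(=O)c1ccc([N+](=O)[O-])cc1`, gives 3300 nM in this assay; the step is a 1.8-fold higher number from compound 1 to compound 2 (0.25 log units; within the scatter), a nitro in place of hydrogen on an aromatic carbon. Compound 3, with the structure `C=C1C(=O)[C@@]23C(=O)OC[C@]4(C(=O)CCC(C)(C)[C@H]4C=O)[C@@H]2CC[C@@H]1[C@H]3OC(=O)c1ccc(F)cc1`, differs from compound 1 as follows: fluoro in place of hydrogen on an aromatic carbon. Within the data shown here, the one step that bears on this change is the step from compound 1 to compound 2, which stayed within the scatter, and it gives no ground for a shift beyond the scatter in this assay. She therefore expects for compound 3 a value near 2200 nM, with a range from 1000 nM to 4800 nM. The expected step is a 1.2-fold higher number from compound 1 to compound 3 (0.08 log units; within the scatter).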

Compound 3, half-maximal inhibitory concentration: 3750 nM
Beside the measured number, compound 3's estimate is 1.7-fold (0.23 log units) below it; the measured number falls inside the stated range.
By their numbers in this assay, from the lowest: compounds 1, 2 and 3 (each within the scatter of the next, the first and the last beyond it).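

In this assay, a change on the aromatic carbon para to a large group now produces a step beyond the scatter: fluoro in place of hydrogen gives a 2.0-fold higher number from compound 1 to compound 3 (0.31 log units; beyond the scatter), a modest step, whereas the nitro change had stayed within it. Fluoro in place of nitro gives a 1.1-fold higher number from compound 2 to compound 3 (0.06 log units; within the scatter), so compound 2 and compound 3 cannot be told apart here. Hydrogen at this place is therefore separated from fluoro but not from nitro, and the two substituents shown fall into no order.

From the compounds shown here alone, how an amine, a carboxylic acid or a methoxy group would read at this place remains open, as does the effect of a longer chain in place of the benzoyl group. The modest step from hydrogen to fluoro stays unexplained. No measurement shown bears on it.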